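This account rests on a few compounds, and the source may have more. Where it says the series, first, only, none or still open, it means among the compounds named here.

In a functional assay on DU-145 cells (Homo sapiens) for cytotoxicity, read by ELISA, with a stated time of 4 days (on this read-out lower numbers stand for stronger inhibition and higher numbers for weaker inhibition), compound 1 `Cc1ccccc1-c1cc(-c2ccoc2)cc(-c2ccc(Cl)s2)n1` gives 18500 nM and compound 2 `Cc1cccc(-c2cc(-c3ccoc3)cc(-c3ccc(Cl)s3)n2)c1` gives 20300 nM. Going by the values given here, the measured step is a 1.1-fold higher number from compound 1 to compound 2 (0.04 log units; within the scatter), so compound 2 stands level with the only other compound measured so far. Compound 3 `Clc1ccc(-c2cc(-c3ccoc3)cc(-c3ccc(Cl)s3)n2)cc1` keeps the shared core and changes one group, with 4-chlorophenyl in place of 3-methylphenyl on an aromatic carbon. Among the compounds with values here, only the step between compound 1 and compound 2 bears on this change, and it exchanges 2-methylphenyl for 3-methylphenyl. Within the data shown here, no compound with a 4-chlorophenyl group has yet been measured, so the data give no firm direction. A step beyond the scatter is therefore not expected in this assay. The expected change is a 1.4-fold lower number from compound 2 to compound 3 (0.13 log units; within the scatter). For compound 3 the estimated value is 15000 nM, with an expected range from 6000 nM to 40000 nM.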

Compound 3, half-maximal inhibitory concentration: 29500 nM
Compound 3: the middle estimate sits 2.0-fold (0.29 log units) below what was measured; the measured number falls inside the stated range.
By their numbers in this assay, from the lowest: compounds 1, 2 and 3 (each within the scatter of the next).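

In this assay, 4-chlorophenyl on the aromatic carbon next to the ring nitrogen gives a 1.5-fold higher number from compound 2 to compound 3 (0.16 log units; within the scatter) against 3-methylphenyl and a 1.6-fold higher number from compound 1 to compound 3 (0.20 log units; within the scatter) against 2-methylphenyl. Going by these compounds alone, the earlier step moved only a methyl group around the phenyl ring, whereas these two replace that methyl with a chlorine at another ring place, and still no step leaves the scatter, so the three substituted phenyl groups stand level here. No measurement is at hand that bears on this result.

The compounds shown leave open whether anything at this position other than a substituted phenyl, such as an amine or a carboxylic acid, would move the number beyond the scatter. They also say nothing about changes to the furan-3-yl or 5-chlorothiophen-2-yl groups.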